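Phenyl in place of ethyl on the saturated chain carbon

The compounds below may be only part of what the source reports. "The series", "measured", "known", "first", "only" and "open" are said of these compounds alone.

compound 1 `CCc1c(C(N)C(=O)O)cnn1O` – > 1000000 nM
compound 2 `CCCc1c(C(N)C(=O)O)cnn1O` – > 1000000 nM
compound 3 `NC(C(=O)O)c1cnn(O)c1-c1ccccc1` – > 1000000 nM

In a functional assay on CHO cells for agonist activity at metabotropic glutamate receptor 1 (Rattus norvegicus), read by calcium flux (on this read-out lower numbers stand for an effect already at smaller amounts and higher numbers for an effect only at larger amounts of compound), compound 1 reaches only a limit of the assay, > 1000000 nM. Compound 2 likewise stands at a limit, > 1000000 nM. Compound 3 also gives a limit, > 1000000 nM. The change from compound 2 to compound 4 `NC(C(=O)O)c1cnn(O)c1Cc1ccccc1` is phenyl in place of ethyl on a saturated chain carbon bound to an aromatic carbon. The single measured step, a step that the two limits leave unreadable from compound 1 to compound 2, cannot be read from two limits, and the limit of > 1000000 nM in this assay, at which 3 of the 3 values shown sit, leaves no step of readable size anywhere among these compounds. Going by the values given here, no measured step therefore bears on the change to compound 4 in a readable way. Compound 4 is expected to sit at a limit as well, estimated at 1000000 nM with a range of 100000 nM to 3000000 nM, which means an expected step of a number no higher from compound 2 to compound 4 (the limit leaves the size open).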

Compound 4, half-maximal effective concentration: > 1000000 nM
Compound 4 was reported as a limit (the forecaster's own chance of this, stated with the estimate: 85%); the middle value lies on the limit itself.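

Compound 4 also stands at a limit, so the steps from compound 1 and compound 2 to compound 4 cannot be read: the limit of > 1000000 nM in this assay, at which 4 of the 4 values shown sit.

The compounds shown leave open whether phenyl in place of ethyl changes anything in this assay.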